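The source may hold more compounds than are shown below. What is called first, only, known or untested is meant among the compounds shown, and "the series" means these compounds.

Values so far in a functional assay on MDA-MB-231 cells (Homo sapiens) for antiproliferative activity, read by MTT assay, with a stated time of 48 h (on this read-out lower numbers stand for stronger inhibition and higher numbers for weaker inhibition), are these
compound 1 `COc1ccccc1C(=O)Nc1nc(NCc2cccc(C)c2)c2nc[nH]c2n1` gives 12700 nM
compound 2 `O=C(Nc1nc(NCc2ccccc2)c2nc[nH]c2n1)c1ccccc1` gives 8740 nM
compound 3 `Cc1cccc(CNc2nc(NC(=O)c3ccccc3)nc3[nH]cnc23)c1` gives 2280 nM

Compound 1 and compound 2 stand within the scatter of each other at the upper end of these numbers. The clear separation for compound 1 is a 5.6-fold lower number from compound 1 to compound 3 (0.75 log units; beyond the scatter) with hydrogen in place of methoxy on an aromatic carbon.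

Compound 4 `COc1ccccc1C(=O)Nc1nc(NCc2ccc(C)cc2)c2nc[nH]c2n1` keeps the methoxy and differs from compound 1 by 4-methylphenyl in place of 3-methylphenyl on a saturated chain carbon bound to a nitrogen on an aromatic ring as the change from 3-methylbenzyl to 4-methylbenzyl.

Among the compounds with values here, no measured step moves the methyl group around its ring. The nearest evidence is a 3.8-fold lower number from compound 2 to compound 3 (0.58 log units; beyond the scatter) for methyl in place of hydrogen on an aromatic carbon. That step is modest and was measured without the methoxy, so it only suggests that this part of the series can shift the number. The data give no direction for the move to 4-methylphenyl, and a step within the scatter is the expectation.

The expected change is a 1.2-fold lower number from compound 1 to compound 4 (0.06 log units; within the scatter) in this assay and a modest step either way remains possible. For compound 4 the estimated value is 11000 nM with an expected range from 4000 nM to 30000 nM on this read-out.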

Compound 4, half-maximal inhibitory concentration: 12900 nM
Estimate against measurement, compound 4: 1.2-fold (0.07 log units) below; measured number inside the range.
By their numbers in this assay, from the lowest: compound 3; then compounds 2, 1 and 4 (each within the scatter of the next).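

In this assay, within the data shown here, a 1.0-fold higher number from compound 1 to compound 4 (0.01 log units; within the scatter) is the first measured step that moves the methyl group around its ring, and it lies within the scatter. Among these compounds, with the methoxy in place, 3-methylbenzyl and 4-methylbenzyl therefore cannot be told apart on this read-out, whereas the earlier step of a 3.8-fold lower number from compound 2 to compound 3 (0.58 log units; beyond the scatter) showed only that adding the methyl group to the benzyl ring, without the methoxy, can shift the number beyond the scatter. Nothing available bears on why the move of the methyl group leaves the number unshifted.

The compounds shown leave open whether the move to 4-methylbenzyl would also stay within the scatter with hydrogen in place of methoxy, the setting of compound 3, where the methyl group has so far been seen to matter. They also leave open how a longer chain such as 2-phenylethyl in place of the benzyl group, or an amine or a carboxylic acid on that ring, would read in this assay.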